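A few compounds are considered here, and "the series" means these few. Any claim that something is new, unique, unknown or untested is made for them only; others in the source may bear on it.

Of the compounds shown here, three sharing one core have so far been measured in a functional assay on the whole organism with Rattus norvegicus as the target; a higher number here means that more compound is needed for the effect, a lower number that less compound is needed. Compound 1 `COc1ccccc1-c1ncc(-c2nn[nH]n2)c(O)n1` gives 0.1 mg/kg, compound 2 `CCOc1ccccc1-c1ncc(-c2nn[nH]n2)c(O)n1` gives 0.09 mg/kg, and compound 3 `CCCOc1ccccc1-c1ncc(-c2nn[nH]n2)c(O)n1` gives 0.04 mg/kg, the lowest number of the three. Compound 4 `CC(C)Oc1ccccc1-c1ncc(-c2nn[nH]n2)c(O)n1` keeps the shared core and departs from compound 3 in one place, with isopropyl in place of propyl on an oxygen on an aromatic ring. The two have the same atoms, joined differently.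

For the measured compounds named here, three measured steps bear on this change, though none of them swaps one of these chains for the other. The data show a 1.1-fold lower number from compound 1 to compound 2 (0.05 log units; within the scatter), which lies within the scatter. They also show a 2.3-fold lower number from compound 2 to compound 3 (0.35 log units; beyond the scatter) and a 2.5-fold lower number from compound 1 to compound 3 (0.40 log units; beyond the scatter), both modest and beyond the scatter. The methyl added on the saturated chain carbon bound to the oxygen thus gave no step beyond the scatter, and only the methyl added two bonds along the chain did. Compound 4 has the same carbon count as compound 3, so no large step is expected in this assay, and at most a slight rise in the number. The expected step is a 1.3-fold higher number from compound 3 to compound 4 (0.10 log units; within the scatter), which would stay within the scatter. For compound 4 the estimated value is 0.05 mg/kg, with an expected range from 0.02 mg/kg to 0.12 mg/kg.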

Compound 4, dose for 50% inhibition: 0.04 mg/kg
The estimate for compound 4 lay 1.3-fold (0.10 log units) above the measured number, and the stated range covers the measured number.
By their numbers in this assay, from the lowest: compounds 3 and 4 (each within the scatter of the next); then compounds 2 and 1 (each within the scatter of the next).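

In this assay there is no change at the digits printed from compound 3 to compound 4 (within the scatter) when the chain on the oxygen on an aromatic ring is branched, so propyl and isopropyl, with the same atoms joined differently, cannot be told apart here. Isopropyl keeps pace with propyl against the shorter chains, showing a 2.3-fold lower number from compound 2 to compound 4 (0.35 log units; beyond the scatter) and a 2.5-fold lower number from compound 1 to compound 4 (0.40 log units; beyond the scatter) as well, so the lower number no longer rests on propyl alone, and a methyl on the saturated chain carbon bound to the oxygen, which earlier gave only a 1.1-fold lower number from compound 1 to compound 2 (0.05 log units; within the scatter) within the scatter, now gives a step beyond it when added to the ethyl chain of compound 2. No measurement among the data accounts for why the two chains read alike or for why the same kind of methyl addition behaves differently in the two cases.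

The compounds shown leave open whether a longer chain such as butyl, or a more branched one such as tert-butyl, on this oxygen would lower the number further or raise it again. They also leave open how a chain ending in an amine or a carboxylic acid would read at this place.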